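The source may report more compounds than this note shows. Statements on the series, on what has been measured and on what is new or still open speak of the compounds shown alone.

Measured so far in a functional assay on T47D cells (Homo sapiens) for inhibition; on this read-out lower numbers stand for stronger inhibition and higher numbers for weaker inhibition:
- compound 1, `Oc1ccc(-c2cc(-c3ccccc3F)cc(-c3ccccc3O)n2)cc1`, gives > 50000 nM, which is a limit of the assay and not a number
- compound 2, `Oc1ccc(-c2cc(-c3cccc(F)c3)cc(-c3ccccc3O)n2)cc1`, gives > 50000 nM, again a limit and not a number
- compound 3, `Oc1cccc(-c2cc(-c3ccccc3C(F)(F)F)cc(-c3ccccc3O)n2)c1`, gives 5680 nM

For the measured compounds named here, compound 3 therefore holds the only true number among the three; the other two sit at the limit of > 50000 nM in this assay, at which 2 of the 3 values shown sit. Going by the values given here, the single measured step, a step that the two limits leave unreadable from compound 1 to compound 2, runs between two limits, so its size cannot be read. Compound 4, `Oc1ccc(-c2cc(-c3ccccc3C(F)(F)F)cc(-c3ccccc3O)n2)cc1`, differs from compound 3 in one place: 4-hydroxyphenyl in place of 3-hydroxyphenyl on an aromatic carbon. Among the compounds with values here, no measured step moves the hydroxyl around this ring, so none bears directly on the change. Compounds 1 and 2 share the 4-hydroxyphenyl with compound 4, yet each carries a fluorophenyl where compound 4 carries a 2-(trifluoromethyl)phenyl, so their limits offer only a hint, not a measurement, that the 4-hydroxyphenyl arrangement may come out weaker. On that hint compound 4 is expected to be somewhat weaker than compound 3 in this assay, by a 2.6-fold higher number from compound 3 to compound 4 (0.42 log units; beyond the scatter), with an estimated value of 15000 nM and a range from 4000 nM to 50000 nM.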

Compound 4, half-maximal inhibitory concentration: 7180 nM
For compound 4 the middle estimate is 2.1-fold (0.32 log units) above the measured one, and the stated range covers the measured number.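

In this assay, 4-hydroxyphenyl in place of 3-hydroxyphenyl gives a 1.3-fold higher number from compound 3 to compound 4 (0.10 log units; within the scatter), so with 2-(trifluoromethyl)phenyl present, this position accepts either arrangement without a readable change. A clear difference appears instead at the other aromatic substituent: 2-(trifluoromethyl)phenyl in place of 3-fluorophenyl gives an at least 6.9-fold lower number from compound 2 to compound 4 (0.84 log units; beyond the scatter), and trifluoromethyl in place of fluoro gives an at least 6.9-fold lower number from compound 1 to compound 4 (0.84 log units; beyond the scatter). Both sizes are only minimum figures, because compound 1 and compound 2 each give a limit and not a number: the limit of > 50000 nM in this assay, at which 2 of the 4 values shown sit.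

Going by these compounds, it remains open whether the same match between 3-hydroxyphenyl and 4-hydroxyphenyl holds when 2-(trifluoromethyl)phenyl is replaced by another group. Also unknown is whether the hydroxyl itself matters at this position, a question that an amine or a carboxylic acid in its place could help to answer.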